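The compounds below may be only part of what the source reports. "The series", "measured", "known", "first", "only" and "open" are said of these compounds alone.

- Compound 1 `CCCc1cn(C/C=C(/C)CCC=C(C)C)nn1`: 4.05
- Compound 2 `COC(=O)c1cn(CC=C(C)C)nn1`: 1.3
- Compound 3 `CC(C)=CCC/C(C)=C\Cn1cc(-c2ccccc2)nn1`: 4.91

These numbers come from a physicochemical assay for lipophilicity, measured as octanol-water partition; a higher number here means a more lipophilic compound, a lower number a more polar compound. Compound 3 stands highest of the three, compound 1 is its nearest neighbour and compound 2 lies furthest away.

The next compound is compound 4 `COC(=O)c1cn(C/C=C(/C)CCC=C(C)C)nn1`, which differs from compound 3 in one place: methoxycarbonyl in place of phenyl on an aromatic carbon. In words, this is methoxycarbonyl in place of phenyl on an aromatic carbon of a five-membered aromatic ring with 3 nitrogen.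

For the measured compounds named here, only one measured step involves this same carbon: a number 0.86 log units higher from compound 1 to compound 3 (beyond the scatter). That step is modest, and it exchanges phenyl for propyl, so it says nothing directly about methoxycarbonyl. The better guide is compound 2, which already carries methoxycarbonyl and gives 1.3. However, compound 2 also differs from compound 4 in the chain on the ring nitrogen. The chain of compound 4 is shared by compound 1, and compound 1 gives 4.05. Going by the values given here, a clear fall in this assay is therefore expected, larger than the one measured step, leaving compound 4 between these two values.

The expected change is a number 1.81 log units lower from compound 3 to compound 4 (beyond the scatter). For compound 4 the estimated value is 3.1, with an expected range from 2.6 to 3.6.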

Compound 4, partition coefficient: 3.2
For compound 4 the middle estimate is 0.10 log units below the measured one; measured number inside the range.
By their numbers in this assay, from the lowest: compound 2; then compound 4; then compound 1; then compound 3.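

On this aromatic carbon of the shared core, methoxycarbonyl gives a clearly lower reading in this assay than either group seen there before: the fall is large against phenyl (a number 1.71 log units lower from compound 3 to compound 4 (beyond the scatter)) and modest against propyl (a number 0.85 log units lower from compound 1 to compound 4 (beyond the scatter)). With the chain on the ring nitrogen held the same, the three groups now form an order with every gap beyond the scatter, with phenyl highest, then propyl, then methoxycarbonyl. For the compounds shown here, compound 4 also adds a first look at the chain itself, since with methoxycarbonyl fixed on the ring, adding 3-methylbut-2-en-1-yl to the chain gives a large rise (a number 1.90 log units higher from compound 2 to compound 4 (beyond the scatter)), and no other measurement here accounts for the size of these steps.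

From the compounds shown here alone, the chain step has been read only with methoxycarbonyl on the ring, so its size with phenyl or propyl in that place remains open. Also open, going by these compounds, is where an amine, a carboxylic acid or a chain longer than propyl on this aromatic carbon would fall in this order.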